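Triazole substituent swap on the shared core

The source may report more compounds than this note shows. Statements on the series, on what has been measured and on what is new or still open speak of the compounds shown alone.

compound 1 `COc1nc2ccc(Br)cc2cc1C(c1ccccc1)n1cc(C2CC2)nn1`: 21.8%
compound 2 `CCCCCCCc1cn(C(c2ccccc2)c2cc3cc(Br)ccc3nc2OC)nn1`: 16.6%

In an ADME assay on PANC-1 cells (Homo sapiens) for cytotoxicity, read by sulforhodamine B assay, with a stated time of 48 h, tested at 10 uM (a lower number here means less inhibition, a higher number more inhibition at the concentration tested (going by the name of the read-out)), compound 2 gives 16.6%, and compound 1 gives 21.8%; the step of a number 5.2 percentage points lower from compound 1 to compound 2 (within the scatter) separates them, so the two numbers sit within the scatter of each other. Compound 3 `COc1nc2ccc(Br)cc2cc1C(c1ccccc1)n1cc(-c2cccc(F)c2)nn1` carries 3-fluorophenyl in place of heptyl on an aromatic carbon. Among the compounds with values here, the one measured step, a number 5.2 percentage points lower from compound 1 to compound 2 (within the scatter), exchanged one non-ring group for another and stayed within the scatter; a ring entering at this carbon has no measured counterpart. No step beyond the scatter is therefore expected for a number 3.4 percentage points higher from compound 2 to compound 3 (within the scatter). Compound 3 is estimated at 20%, with a range from 6% to 36%.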

Compound 3, a percentage reported as inhibition, at one concentration (the size of the read-out at that concentration, not a potency): 15.5%
The estimate for compound 3 lay 4.5 percentage points above the measured number; low and high end bracket the measured number.
By their numbers in this assay, from the lowest: compounds 3, 2 and 1 (each within the scatter of the next).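

Within this assay 3-fluorophenyl in place of heptyl gives a number 1.1 percentage points lower from compound 2 to compound 3 (within the scatter) and 3-fluorophenyl in place of cyclopropyl gives a number 6.3 percentage points lower from compound 1 to compound 3 (within the scatter) on the same aromatic carbon. An aromatic ring at this carbon therefore separates from neither the open chain nor the cyclopropyl group, so all three groups read alike here. Nothing available explains this flat response.

As far as these compounds go, whether an amine or a carboxylic acid on this carbon would move the number beyond the scatter remains open. The contribution of the fluorine itself also remains open, with no unsubstituted phenyl among these compounds.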